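From a six-membered to a five-membered ring group

The source may hold more compounds than are shown below. What is called first, only, known or untested is meant among the compounds shown, and "the series" means these compounds.

Compound 1 `CC1(C)C=C(n2ccccc2=O)c2cc(C#N)ccc2O1` gives 50 nM in a functional assay for inhibition, with Sus scrofa as the target (on this read-out higher numbers stand for weaker inhibition and lower numbers for stronger inhibition), and compound 2 `CC1(C)Oc2ccc(C#N)cc2[C@@H](Oc2ccccn2)[C@]1(C)O` gives 6000 nM there. Compound 3 `CC1=C(n2ccccc2=O)c2cc(C#N)ccc2OC1(C)C` gives 5000 nM here, within the scatter of compound 2 and far from compound 1. For the measured compounds named here, the one measured step is a 100-fold higher number from compound 1 to compound 3 (2.00 log units; beyond the scatter) and it concerns the methyl group, not the group that changes now. Going by the values given here, compound 4 `CC1=C(N2CCCC2=O)c2cc(C#N)ccc2OC1(C)C` keeps that methyl group and differs in another way: a group of 6 heavy atoms (4 carbon, 1 nitrogen, 1 oxygen; one five-membered non-aromatic ring with 1 hetero atom) in place of a group of 7 heavy atoms (5 carbon, 1 nitrogen, 1 oxygen; one six-membered aromatic ring with 1 hetero atom), on a double-bonded ring carbon and no measured step covers such a swap. With no direction favoured, the estimated step is no change at the digits printed from compound 3 to compound 4 (within the scatter) so none beyond the scatter is expected in this assay for this change. Compound 4 is expected to read 5000 nM with a range of 1200 nM to 20000 nM in this estimate.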

Compound 4, half-maximal inhibitory concentration: > 100000 nM
Compound 4 gave a limit, no number (the forecaster's own chance of this, stated with the estimate: 15%); middle value at least 20-fold (1.30 log units) away from the limit.
By their numbers in this assay, from the lowest: compound 1; then compounds 3 and 2 (each within the scatter of the next). At a limit, above all of these: compound 4.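

In this assay, the group on the double-bonded ring carbon turns out to matter as well: 2-oxopyrrolidin-1-yl in place of the six-membered aromatic ring gives an at least 20-fold higher number from compound 3 to compound 4 (1.30 log units; beyond the scatter). For the compounds shown here, the earlier compounds offered a measured step only for the methyl group, so this is the first sign that this group can also move the number strongly. Compound 4 stands at a limit, not a number: the limit of > 100000 nM in this assay, at which 1 of the 4 values shown sits.

On these data alone, whether the same swap would count as heavily without the methyl group, on the core of compound 1, stays open. Also open, as far as these compounds go, is how 2-oxopiperidin-1-yl, a six-membered non-aromatic ring, would read, which could separate the effect of ring size from that of the aromatic ring.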